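A few compounds are considered here, and "the series" means these few. Any claim that something is new, unique, unknown or untested is made for them only; others in the source may bear on it.

Notes on a three-compound set in an ADME assay on microsomes from liver (Homo sapiens) for metabolic stability, tested at 2.5 uM; a higher number here means faster removal of the compound, a lower number slower removal. Compound 1 `O=S(=O)(c1ccc(F)c(F)c1)c1cnc2c(F)cccc2c1-c1ccccc1F` gives 1.39 mL/min, the highest of the three numbers. Among the measured compounds shown here, compound 2 `O=S(=O)(c1cc(Cl)cc(Cl)c1)c1cnc2c(F)cccc2c1-c1ccccc1F` gives 0.44 mL/min; the one single-point step in the set, a 3.2-fold lower number from compound 1 to compound 2 (0.50 log units; beyond the scatter), comes from 3,5-dichlorophenyl in place of 3,4-difluorophenyl on a sulfonyl sulfur. Compound 3 `O=S(=O)(c1ccc(F)c(Cl)c1)c1cnc2cc(F)ccc2c1-c1ccc(Cl)cc1` gives 0.39 mL/min; compound 3 differs from compound 1 in more than one place, so its gap to compound 1 is not read as a single step.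

Compound 4 `O=S(=O)(c1ccc(F)c(F)c1)c1cnc2c(F)cccc2c1-c1cccc(F)c1` is not yet measured. It differs from compound 1 as follows: 3-fluorophenyl in place of 2-fluorophenyl on an aromatic carbon. For the measured compounds named here, no measured step touches this aromatic carbon; the only step available alters the group on a sulfonyl sulfur, and that step was modest. Going by the values given here, the two structures hold the same atoms, joined differently, and the set gives no precedent for this kind of change. The expected step of a 1.2-fold lower number from compound 1 to compound 4 (0.06 log units; within the scatter) is therefore none beyond the scatter, with compound 1 as the anchor. Compound 4 is estimated at 1.2 mL/min, with a range from 0.6 mL/min to 2.5 mL/min.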

Compound 4, intrinsic clearance in a liver preparation (reported as CLH), per the amount of preparation that the assay uses: 1.28 mL/min
For compound 4 the middle estimate is 1.1-fold (0.03 log units) below the measured one, within the range that was stated.
By their numbers in this assay, from the lowest: compounds 3 and 2 (each within the scatter of the next); then compounds 4 and 1 (each within the scatter of the next).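

In this assay, among the compounds shown here, 3-fluorophenyl in place of 2-fluorophenyl on this aromatic carbon of the shared core gives a 1.1-fold lower number from compound 1 to compound 4 (0.04 log units; within the scatter) as the first single-place reading at this position. For the compounds shown here, the change of attachment within the fluorophenyl group therefore leaves compound 1 and compound 4 indistinguishable in this read-out, in contrast to the only other single-place step, a 3.2-fold lower number from compound 1 to compound 2 (0.50 log units; beyond the scatter) on the sulfonyl sulfur. No measured evidence on hand bears on why these two compounds read alike.

As far as these compounds go, only 2-fluorophenyl and 3-fluorophenyl are compared at this aromatic carbon in a single-place pair, so the effect of an amine or a carboxylic acid on that phenyl group remains open. Also open, from the compounds shown here alone, is whether the same swap would read alike with the 3,5-dichlorophenyl group of compound 2 on the sulfonyl sulfur.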